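Pentan-3-yl sulfone to isopropylsulfamoyl on a disulfonyl scaffold

The compounds below may be only part of what the source reports. "The series", "measured", "known", "first", "only" and "open" are said of these compounds alone.

Measured compounds:
compound 1 `CCOC(=O)[C@@H]1CCN(S(=O)(=O)c2ccc(S(=O)(=O)N(CC)CC)cc2)C1`: 10000 nM
compound 2 `CCC(CC)S(=O)(=O)c1ccc(S(=O)(=O)N2CCC[C@@H](C(=O)N3CCN(c4nc(C(C)C)no4)CC3)C2)cc1`: 120 nM

Compound 2 stands at the lowest of the two numbers in a functional assay on BXPC-3 cells (Homo sapiens) for inhibition, read by MTT assay, with a stated time of 7 days; a higher number here means a weaker inhibitor, a lower number a stronger inhibitor. Its nearest neighbour is compound 1, which gives 10000 nM in this assay, a gap well beyond the scatter; the two differ in several places at once, so only their two values can be compared. Compound 3 `CC(C)NS(=O)(=O)c1ccc(S(=O)(=O)N2CCC[C@@H](C(=O)N3CCN(c4nc(C(C)C)no4)CC3)C2)cc1` is not yet measured. It differs from compound 2 in a single place: isopropylamino in place of pentan-3-yl on a sulfonyl sulfur. The sulfonyl sulfur carries the new group, the aromatic carbon attached to it being unchanged. Among the compounds with values here, no measured pair shows this exact exchange, so the size of the step is uncertain. Within the data shown here, the one other compound, compound 1, carries a sulfamoyl group and shows a much higher number, but it also differs elsewhere, so it offers no clean guide. Compound 3 is expected to give a moderately higher number than compound 2, an estimated step of a 2.5-fold higher number from compound 2 to compound 3 (0.40 log units; beyond the scatter). For compound 3 the estimate in this assay is 300 nM, with a range from 100 nM to 1500 nM.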

Compound 3, half-maximal inhibitory concentration: 2600 nM
Beside the measured number, compound 3's estimate is 8.7-fold (0.94 log units) below it, outside the stated range (above it).
By their numbers in this assay, from the lowest: compound 2; then compound 3; then compound 1.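

Within the data shown here, the exchange of pentan-3-yl for isopropylamino on a sulfonyl sulfur is the first change that can be read in a single place, and in this assay it gives a 22-fold higher number from compound 2 to compound 3 (1.34 log units; beyond the scatter), with the rest of the molecule held constant. This shows that the number is highly sensitive to what this sulfonyl sulfur carries: replacing an all-carbon group with one of similar size that contains a nitrogen and brings a hydrogen-bond donor is enough to produce a large step, something compound 1 could not show since it differs from compound 2 in several places at once. Nothing measured here accounts for the size of this step.

The compounds shown do not separate the contribution of the nitrogen and its hydrogen from that of the shorter carbon branches, since both change together in this one exchange. As far as these compounds go, an isopropyl group placed directly on the same sulfonyl sulfur, or a methyl(isopropyl)amino group there, would pull these two parts apart, and how either would read in this assay remains open.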